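The source may report more compounds than this note shows. Statements on the series, on what has been measured and on what is new or still open speak of the compounds shown alone.

Working notes on the shared core of compound 1, `Nc1cc(N)c2nc(-c3ccccc3)c(NCc3ccc(Cl)c(Cl)c3)nc2c1`, and its two close relatives, compound 2, `Nc1cc(N)c2nc(-c3ccccc3)c(Sc3ccc(F)cc3)nc2c1`, and compound 3, `Nc1cc(N)c2nc(-c3ccccc3)c(Oc3ccc(F)cc3)nc2c1`. In a functional assay on NCI-H23 cells (Homo sapiens) for inhibition, read by sulforhodamine B assay, with a stated time of 48 h (a higher number here means a weaker inhibitor of growth, a lower number a stronger inhibitor of growth), compound 1 gives 27500 nM. In this assay compound 2 gives 39800 nM and compound 3 gives 39800 nM; both of these sit within the scatter of the value of compound 1, so the three measured compounds are not separated from one another by these numbers. Within the data shown here, the one single-point step among them, no change at the digits printed from compound 2 to compound 3 (within the scatter), concerns the group on the aromatic carbon and not the benzylic side, so it says nothing direct about the change now in question.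

Among the measured compounds shown here, compound 4, `COc1ccc(CNc2nc3cc(N)cc(N)c3nc2-c2ccccc2)cc1`, differs from compound 1 as follows. 4-methoxyphenyl in place of 3,4-dichlorophenyl on a saturated chain carbon bound to a nitrogen on an aromatic ring No measured pair shows this change, and the only measured step is flat. With three values that all fall together and no step beyond the scatter anywhere, the expectation for compound 4 is a number close to that of compound 1, with no shift beyond the scatter in either direction; the step from compound 1 to compound 4 is expected to come out as a 1.3-fold higher number from compound 1 to compound 4 (0.10 log units; within the scatter). For compound 4 in this assay the estimate is 35000 nM, with a range from 14000 nM to 85000 nM.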

Compound 4, concentration for total growth inhibition: 34700 nM
Beside the measured number, compound 4's estimate is 1.0-fold (0.00 log units) above it, and the stated range covers the measured number.
By their numbers in this assay, from the lowest: compounds 1, 4, 2 and 3 (each within the scatter of the next).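

The series now has its first direct reading on the benzylic side of the shared core: in this assay the exchange of 3,4-dichlorobenzyl for 4-methoxybenzyl gives no separation between the two compounds (a 1.3-fold higher number from compound 1 to compound 4 (0.10 log units; within the scatter)). Among these compounds, the earlier step spoke only to the group on the aromatic carbon, so this is the first sign that the substituents on this benzyl ring can differ without a shift beyond the scatter. The pair swaps two chlorine atoms for a single methoxy group and adds a hydrogen-bond acceptor to the leaving group's count of none, and the read-out does not register this difference.

Going by these compounds, both benzyl groups carry a six-membered aromatic ring of carbon only, so it remains open whether an amine, a carboxylic acid or a longer chain on the saturated chain carbon would move the number beyond the scatter. Also open, on these data alone, is whether a pyridine ring in place of the benzyl ring's benzene would leave the value in the same range.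

No supporting measurement bears on why this step is flat.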